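Plasma Stability When Pyridazin-3-yl Replaces Thiophen-2-yl

The source may report more compounds than this note shows. Statements on the series, on what has been measured and on what is new or still open speak of the compounds shown alone.

In an ADME assay on a cell-free system (plasma, Homo sapiens) for metabolic stability, read by LC-MS, with a stated time of 4 h, tested at 100 uM (a higher number here means that more of the compound is left, a lower number that less of the compound is left), compound 1 `O=C(NO)c1cc(F)c(Cn2nnc(-c3ccco3)n2)c(F)c1` gives 100% and compound 2 `Cn1c(Sc2ccc(C(=O)NO)cc2)nnc1-c1cccs1` gives 100% of the parent. Compound 3 `Cn1c(Sc2c(F)cc(C(=O)NO)cc2F)nnc1-c1cccs1` gives 99% and so lies within the scatter of both. Compound 4 `Cn1c(Sc2c(F)cc(C(=O)NO)cc2F)nnc1-c1cccnn1` has pyridazin-3-yl in place of thiophen-2-yl on an aromatic carbon, between two ring nitrogen atoms (pyridazin-3-yl in place of thiophen-2-yl on an aromatic carbon). Going by the values given here, no step between measured compounds covers this change, so the expectation rests on the values alone, chiefly compound 3 at 99% in this assay here. The expected step (a number 2 percentage points lower from compound 3 to compound 4 (within the scatter)) stays within the scatter, with no clear direction. Compound 4 is estimated at 97% (range 88% to 100%).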

Compound 4, percent of the compound remaining: 100%
Beside the measured number, compound 4's estimate is 3 percentage points below it; low and high end bracket the measured number.
By their numbers in this assay, from the lowest: compounds 3, 1, 2 and 4 (each within the scatter of the next).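

In this assay the change from thiophen-2-yl to pyridazin-3-yl on the aromatic carbon between two ring nitrogen atoms gives a number 1 percentage points higher from compound 3 to compound 4 (within the scatter) at this place. Compound 2 and compound 3 carry only thiophen-2-yl here, so this step adds a six-membered aromatic ring with 2 hetero atoms and shows no clear shift in the amount left. Nothing at hand bears on why the amount left holds.

On these data alone, whether an amine or a carboxylic acid on this carbon would leave as much of the compound remains open. So does the effect of a longer chain there.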